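This account rests on a few compounds, and the source may have more. Where it says the series, first, only, none or still open, it means among the compounds named here.

Working notes on the series, all read in a functional assay on KARPAS-422 cells (Homo sapiens) for antiproliferative activity, read by resazurin assay, with a stated time of 72 h; on this read-out lower numbers stand for stronger inhibition and higher numbers for weaker inhibition. Compound 1 `COC(c1cc(Cl)c2c(c1Cl)C(=O)N(Cc1c(C)cc(C)[nH]c1=O)CC2)C1CCOCC1` stands at 1150 nM; 19 nM (2 entries) and compound 3 `Cc1cc(C)c(CN2CCc3c(Cl)cc(C(CO)c4ccon4)c(Cl)c3C2=O)c(=O)[nH]1` stands at 2490 nM; 122 nM (2 entries), so the entries for each of these compounds lie far apart. Among the compounds with values here, compound 2 `Cc1cc(C)c(CN2CCc3c(Cl)cc([C@H](CO)[C@H]4CCCO4)c(Cl)c3C2=O)c(=O)[nH]1` gives 63 nM as the only single number in the set. That number falls inside the span of compound 1 and close to the lower entry of compound 3, so it is a usable reference but not a firm rank.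

The next compound is compound 4 `Cc1cc(C)c(CN2CCc3c(Cl)cc(-c4c(C)noc4C)c(Cl)c3C2=O)c(=O)[nH]1`, and the change is a group of 7 heavy atoms (5 carbon, 1 nitrogen, 1 oxygen; one five-membered aromatic ring with 2 hetero atoms) in place of a group of 8 heavy atoms (6 carbon, 2 oxygen; one five-membered non-aromatic ring with 1 hetero atom), on an aromatic carbon. The entering group is 3,5-dimethyl-1,2-oxazol-4-yl, on an aromatic carbon ortho to a chloro group and meta to a chloro group.

Within the data shown here, no measured pair isolates this change, so any expectation is loose. The nearest guide is compound 3, which also carries a five-membered aromatic ring with 2 hetero atoms and reads 2490 nM; 122 nM (2 entries), with an upper entry well away from the reference. A loss of potency is therefore expected, estimated as a 6.3-fold higher number from compound 2 to compound 4 (0.80 log units; beyond the scatter) and likely to exceed the usual scatter. For this assay compound 4 is estimated at 400 nM with an expected range of 80 nM to 2500 nM as the working figure.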

Compound 4, half-maximal inhibitory concentration: 23 nM
Beside the measured number, compound 4's estimate is 17-fold (1.24 log units) above it; measured number outside the range, below it.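

In this assay, within the data shown here, placing the 3,5-dimethyl-1,2-oxazol-4-yl group on this aromatic carbon gives a 2.7-fold lower number from compound 2 to compound 4 (0.44 log units; beyond the scatter), the first step at this position that can be read between two single numbers. A five-membered aromatic ring with 2 hetero atoms is therefore accepted here without loss, and the number improves even though the hydrogen-bond donor and the 2 defined stereocentres of the leaving group are gone. Compound 3 also carries a five-membered aromatic ring with 2 hetero atoms, yet compound 4 at 23 nM lies under both of its entries, so the presence of such a ring does not alone set the reading at this position, and the size of the gap stays loose, and compound 1 cannot be ranked against compound 4 at all, given the spread in both compounds: the several entries of compound 3 in this assay, 2490 nM; 122 nM (2 entries)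

Whether the improvement comes from the ring itself or from its two methyl groups stays open, since the unsubstituted 1,2-oxazol-4-yl ring is not among the compounds shown. On these data alone, how an amine or a carboxylic acid on this aromatic carbon would read also remains unknown.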